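Lengthening the Ester Chain: Propyl to Isobutyl

The source may report more compounds than this note shows. Statements on the series, on what has been measured and on what is new or still open speak of the compounds shown alone.

Two compounds have so far been measured in an assay on membranes from HeLa cells for displacement of a labelled ligand from adenosine receptor A3 (Homo sapiens), read by scintillation counting, with a stated time of 180 min, tested at 1 uM; a lower number here means less inhibition, a higher number more inhibition at the concentration tested (going by the name of the read-out):

Compound 1, `COC(=O)C1=C(C)NC(=S)NC1c1ccoc1`: 3%
Compound 2, `CCCOC(=O)C1=C(C)NC(=S)NC1c1ccoc1`: 3%

Both numbers are low, meaning little of the labelled ligand is displaced at the concentration tested. Compound 2 stands level with compound 1 on the numbers shown: the only measured step, no change at the digits printed from compound 1 to compound 2 (within the scatter), lies within the scatter.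

The next compound, compound 3, `CC1=C(C(=O)OCC(C)C)C(c2ccoc2)NC(=S)N1`, differs from compound 2 in one place: methyl in place of hydrogen on a saturated chain carbon bound to two saturated chain carbons. Going by the values given here, only one measured step bears on this change. That step, no change at the digits printed from compound 1 to compound 2 (within the scatter), grew the same chain on the oxygen of the ester and left the read-out unchanged. Since growing the chain once did nothing, a further branch of one carbon on that chain is expected to leave the read-out where it is, so the expected step of no change at the digits printed from compound 2 to compound 3 (within the scatter) is none beyond the scatter. Compound 3 is therefore estimated at 3%, with a range from 0% to 12%.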

Compound 3, a percentage reported as inhibition, at one concentration (the size of the read-out at that concentration, not a potency): 1%
Estimate against measurement, compound 3: 2 percentage points above; the measured number falls inside the stated range.
By their numbers in this assay, from the lowest: compounds 3, 1 and 2 (each within the scatter of the next).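

The branch itself, methyl in place of hydrogen on a saturated chain carbon bound to two saturated chain carbons, gives a number 2 percentage points lower from compound 2 to compound 3 (within the scatter) in this assay, so this first branched chain cannot be told apart from the straight propyl chain by this read-out. Set against the shortest ester in the set, the larger change in the ester chain gives a number 2 percentage points lower from compound 1 to compound 3 (within the scatter), so the three ester chains shown, whether straight or branched, all read alike within the scatter. No measurement at hand offers an explanation for these low readings, and nothing here separates a real absence of effect from differences too small to see at one concentration.

The compounds shown leave open whether a much longer chain such as octyl, or a chain ending in an amine or a carboxylic acid, would lift the read-out out of this low range. They also say nothing about changes elsewhere on the shared core, since all three differ only in the ester chain.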